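Ring-Edge Substituents and Acid Dissociation in Compound 4

The compounds below may be only part of what the source reports. "The series", "measured", "known", "first", "only" and "open" are said of these compounds alone.

Measured compounds:
compound 1, `COc1ccc(F)cc1CNCCCNc1ccnc2cc(CCC(C)C)ccc12`, 9.47
compound 2, `COc1ccc(F)cc1CNCCCNc1ccnc2cc(CCc3ccccc3)ccc12`, 9.47
compound 3, `COc1ccc(F)cc1CNCCCNc1ccnc2cc(Cc3ccc(F)cc3)ccc12`, 9.47

In a physicochemical assay for acid dissociation, compound 1 gives 9.47, compound 2 gives 9.47 and compound 3 gives 9.47. The three compounds share one core and differ only in the group carried on the aromatic carbon of the fused ring system. The steps between them are no change at the digits printed from compound 1 to compound 2 (within the scatter), no change at the digits printed from compound 1 to compound 3 (within the scatter) and no change at the digits printed from compound 2 to compound 3 (within the scatter). Compound 3 therefore stands level with compounds 1 and 2 in this assay, with no value set apart from the others.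

Compound 4, `COc1ccc(F)cc1CNCCCNc1ccnc2cc(Oc3ccc(C(C)(C)C)cc3)ccc12`, has not yet been measured. It differs from compound 3 as follows: 4-(tert-butyl)phenoxy in place of 4-fluorobenzyl on an aromatic carbon. The change sits on the same aromatic carbon that was varied across the three measured compounds, where isobutyl, phenethyl and 4-fluorobenzyl all left this assay unchanged. Those three steps bear directly on the present one, and each was within the scatter. The estimate for compound 4 in this assay is therefore 9.47, with a range from 9.2 to 9.75, so that the step of no change at the digits printed from compound 3 to compound 4 (within the scatter) is expected to be no larger than the scatter.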

Compound 4, acid dissociation constant: 9.28
Beside the measured number, compound 4's estimate is 0.19 log units above it, and the stated range covers the measured number.
By their numbers in this assay, from the lowest: compounds 4, 1, 2 and 3 (each within the scatter of the next).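

In this assay the exchange of 4-fluorobenzyl for 4-(tert-butyl)phenoxy gives a number 0.19 log units lower from compound 3 to compound 4 (within the scatter) on this aromatic carbon, while the same group in place of phenethyl gives a number 0.19 log units lower from compound 2 to compound 4 (within the scatter) and in place of isopentyl gives a number 0.19 log units lower from compound 1 to compound 4 (within the scatter) at the same carbon. The earlier compounds shown here all carried a saturated chain carbon on this position, so the new result extends the reading within the scatter to a group attached through oxygen, one that enters with a hydrogen-bond acceptor and a larger heavy-atom count than the 4-fluorobenzyl that leaves. Nothing measured here accounts for the printed number of compound 4.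

In this step the oxygen link and the tert-butyl group enter together, so the compounds shown do not separate their contributions, which a plain phenoxy or a 4-(tert-butyl)benzyl group on the same carbon could do. They also leave open whether an amine or a carboxylic acid at this aromatic carbon would stay within the scatter in this assay for the shared core.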